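The compounds below may be only part of what the source reports. "The series", "measured", "known", "first", "only" and "open" are said of these compounds alone.

Measured so far:
- Compound 1 `CNC(=O)O[C@@H]1CO[C@]2(COC(C)(C)O2)[C@@](O)(C2(C)CO2)[C@@H]1OC`: 195000 nM
- Compound 2 `CO[C@@H]1[C@H](OC(=O)NC(=O)CCl)CO[C@]2(COC(C)(C)O2)[C@]1(CCCCCc1ccccc1)OC(=O)NC(=O)CCl`: 800 nM

In a functional assay on cells (Endothelial cell, Sus scrofa) for antiproliferative activity (on this read-out higher numbers stand for weaker inhibition and lower numbers for stronger inhibition), compound 1 gives the higher of these two numbers, and compound 2 sits far lower; the two differ in more than one place, so only their two values are compared here. Compound 3 `CO[C@@H]1[C@H](OC(=O)NC(=O)c2ccccc2)CO[C@]2(COC(C)(C)O2)[C@@]1(O)C1(C)CO1` is not yet measured. It differs from compound 1 in one place: benzoyl in place of methyl on an amide-type nitrogen. Among the compounds with values here, with no single-change step between measured compounds to lean on, a moderate move toward stronger inhibition is expected, a 6.5-fold lower number from compound 1 to compound 3 (0.81 log units; beyond the scatter). Compound 3 is therefore estimated at 30000 nM, within a range of 5000 nM to 150000 nM.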

Compound 3, half-maximal inhibitory concentration: 363000 nM
Beside the measured number, compound 3's estimate is 12-fold (1.08 log units) below it, and the stated range ends below it.
By their numbers in this assay, from the lowest: compound 2; then compounds 1 and 3 (each within the scatter of the next).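

In this assay, putting benzoyl in place of methyl on the amide-type nitrogen gives a 1.9-fold higher number from compound 1 to compound 3 (0.27 log units; within the scatter), so the two compounds cannot be told apart. On this core, then, this nitrogen carries either a single methyl or a benzoyl with its aromatic ring with no measurable difference in the read-out. No measurement at hand explains this result.

From the compounds shown here alone, whether a shorter acetyl group, a longer alkyl chain or a group carrying a carboxylic acid on this same nitrogen would move the number remains open.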